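Swapping the styryl arm for a tolyl group

The compounds below may be only part of what the source reports. "The series", "measured", "known", "first", "only" and "open" are said of these compounds alone.

Measured compounds:
compound 1 `COC(=O)/C=C/c1cccc(N(Cc2ccc(/C=C/c3c(C)cc(C)cc3C)cc2)C(=O)C(C)C)c1` — 149 nM
compound 2 `COC(=O)/C=C/c1cccc(N(Cc2ccc(/C=C/c3c(C)cc(C)cc3C)cc2)C(=O)NC(C)C)c1` — 431 nM
compound 3 `COC(=O)/C=C/c1cccc(N(Cc2ccc(-c3ccc(OC)cc3)cc2)C(=O)C2CCCCC2)c1` — 89 nM

In an assay on isolated protein with Bile acid receptor (Homo sapiens) as the target (on this read-out lower numbers stand for an effect already at smaller amounts and higher numbers for an effect only at larger amounts of compound), compound 1 gives 149 nM, the second highest of the three numbers. Compound 3 sits within the scatter of it, while compound 2 lies beyond it: a 2.9-fold higher number from compound 1 to compound 2 (0.46 log units; beyond the scatter). That one step concerns the group on the carbonyl carbon and says nothing direct about the arm carried on the benzyl ring.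

Compound 4 `COC(=O)/C=C/c1cccc(N(Cc2ccc(-c3ccc(C)cc3)cc2)C(=O)C(C)C)c1` is that arm changed: 4-methylphenyl in place of 2-(2,4,6-trimethylphenyl)ethenyl on an aromatic carbon. Within the data shown here, no measured pair isolates this change. Compound 3 carries a biaryl arm of related shape together with a different carbonyl substituent and gives 89 nM, which shows that a compact aryl group in this position can sit in the same range as compound 1.

Compound 4 is therefore expected to show a 1.3-fold higher number from compound 1 to compound 4 (0.13 log units; within the scatter), a change not clearly beyond the scatter. The estimate for compound 4 is 200 nM, within 70 nM to 600 nM.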

Compound 4, half-maximal effective concentration: 118 nM
Compound 4: middle estimate off by 1.7-fold (0.23 log units), on the high side; measured number inside the range.
By their numbers in this assay, from the lowest: compounds 3, 4 and 1 (each within the scatter of the next); then compound 2.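

In this assay, replacing the 2-(2,4,6-trimethylphenyl)ethenyl arm with 4-methylphenyl gives a 1.3-fold lower number from compound 1 to compound 4 (0.10 log units; within the scatter). This single-place comparison shows that, in the setting of compound 1, the arm on this aromatic carbon can lose its double bond outside aromatic rings and go from 11 heavy atoms to 7 while the read-out stays within the scatter. Nothing available here bears on why the two arms give such similar numbers.

From the compounds shown here alone, it remains open whether 4-methylphenyl would behave the same way alongside the isopropylamino group of compound 2. The compounds shown also leave open how this position would respond to a more distinct aryl arm, such as a 4-aminophenyl group or a 4-carboxyphenyl group.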